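Swapping a Methyl for a Benzyl on the Ring Nitrogen

This account rests on a few compounds, and the source may have more. Where it says the series, first, only, none or still open, it means among the compounds named here.

Of the compounds shown here, three sharing one core have been tested in a functional assay on trachea (Cavia porcellus); a higher number here means a weaker inhibitor, a lower number a stronger inhibitor. Compound 1 `CO[C@@]12CCN(Cc3ccccc3)C[C@H]1[C@H](c1ccc(Cl)cc1Cl)C(C#N)=C(N)O2` gives 18300 nM, compound 2 `CO[C@@]12CCN(Cc3ccccc3)C[C@H]1[C@H](c1ccc(C)cc1)C(C#N)=C(N)O2` gives 27100 nM, and compound 3 `COc1ccc([C@@H]2C(C#N)=C(N)O[C@]3(OC)CCN(C)C[C@@H]23)cc1` gives 23100 nM. Among the measured compounds shown here, the only single-point step, a 1.5-fold higher number from compound 1 to compound 2 (0.17 log units; within the scatter), changes the aryl group on the saturated ring carbon. Compound 3 stands second highest of the three, yet all three numbers lie within the scatter of one another. Compound 4 `COc1ccc([C@@H]2C(C#N)=C(N)O[C@]3(OC)CCN(Cc4ccccc4)C[C@@H]23)cc1` differs from compound 3 by phenyl in place of hydrogen on a saturated chain carbon bound to an amine nitrogen in a ring. For the measured compounds named here, no measured step touches that position; compounds 1 and 2, which already carry the benzyl group, give numbers within the scatter of compound 3. The expected step of a 1.0-fold lower number from compound 3 to compound 4 (0.00 log units; within the scatter) is therefore none beyond the scatter. Compound 4 is estimated at 23000 nM, with a range from 9000 nM to 60000 nM.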

Compound 4, half-maximal inhibitory concentration: 23100 nM
Compound 4: middle estimate off by 1.0-fold (0.00 log units), on the low side, within the range that was stated.
By their numbers in this assay, from the lowest: compounds 1, 3, 4 and 2 (each within the scatter of the next).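

In this assay, among the compounds shown here, the swap from methyl to benzyl gives no change at the digits printed from compound 3 to compound 4 (within the scatter) and is the only direct reading at this position, so compounds with either group stand within the scatter. The other two comparisons also stay within it: methoxy in place of methyl on an aromatic carbon gives a 1.2-fold lower number from compound 2 to compound 4 (0.07 log units; within the scatter) and 4-methoxyphenyl in place of 2,4-dichlorophenyl gives a 1.3-fold higher number from compound 1 to compound 4 (0.10 log units; within the scatter) with the benzyl group present. Nothing available here explains these readings. As far as these compounds go, whether an amine, a carboxylic acid or a longer chain at this position would move the number beyond the scatter remains open.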